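From compound 3 to compound 4

The source may report more compounds than this note shows. Statements on the series, on what has been measured and on what is new or still open speak of the compounds shown alone.

In an ADME assay on HEK293 cells (Homo sapiens) for cytotoxicity, read by MTT assay, with a stated time of 24 h (a lower number here means a stronger inhibitor, a higher number a weaker inhibitor), compound 3 `COc1ccccc1CNc1nc2ccc([N+](=O)[O-])cc2nc1NCCCN(C)C` gives 36.1 ug/mL and compound 2 `COc1ccc(CNc2nc3ccc([N+](=O)[O-])cc3nc2NCCCN(C)C)cc1` gives 38.6 ug/mL. The two share the upper end of the three numbers, with a 1.1-fold lower number from compound 2 to compound 3 (0.03 log units; within the scatter). Compound 1 `CN(C)CCCNc1nc2cc([N+](=O)[O-])ccc2nc1NCc1ccc(Cl)cc1` stands lower at 10.7 ug/mL.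

Compound 4 `CN(C)CCCNc1nc2cc([N+](=O)[O-])ccc2nc1NCc1ccc(Cl)c(C(F)(F)F)c1` differs from compound 3 as follows: 4-chloro-3-(trifluoromethyl)phenyl in place of 2-methoxyphenyl on a saturated chain carbon bound to a nitrogen on an aromatic ring. The closest measured guide is a 3.4-fold higher number from compound 1 to compound 3 (0.53 log units; beyond the scatter), a modest step, and a 3.6-fold higher number from compound 1 to compound 2 (0.56 log units; beyond the scatter) is of similar size. Both run from the chloro compound to a methoxy compound, so the change to compound 4 runs the opposite way. For the measured compounds named here, no measured compound carries trifluoromethyl, so that part remains untested. A modest drop is expected, a 3.6-fold lower number from compound 3 to compound 4 (0.56 log units; beyond the scatter). Compound 4 is estimated at 10 ug/mL, with an expected range of 4.5 ug/mL to 22 ug/mL.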

Compound 4, half-maximal inhibitory concentration: 3.26 ug/mL
The estimate for compound 4 lay 3.1-fold (0.49 log units) above the measured number; the measured number lies below the stated range.
By their numbers in this assay, from the lowest: compound 4; then compound 1; then compounds 3 and 2 (each within the scatter of the next).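

In this assay, trifluoromethyl in place of hydrogen on an aromatic carbon takes the number lower still, a 3.3-fold lower number from compound 1 to compound 4 (0.52 log units; beyond the scatter), so the chloro compound does not mark the low end for this group. Against the methoxy compounds, the 4-chloro-3-(trifluoromethyl)phenyl group gives large steps, an 11-fold lower number from compound 3 to compound 4 (1.04 log units; beyond the scatter) and a 12-fold lower number from compound 2 to compound 4 (1.07 log units; beyond the scatter), where chloro alone gave only modest ones. Nothing available accounts for the drop.

As far as these compounds go, whether trifluoromethyl without the chloro gives the same drop stays open. So does whether a nitrile or a carboxylic acid in place of trifluoromethyl would keep it.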